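This account rests on a few compounds, and the source may have more. Where it says the series, first, only, none or still open, it means among the compounds named here.

Working notes on the series, all read in an ADME assay on MT4 cells (Homo sapiens) for cytotoxicity, read by MTT assay, with a stated time of 5 days; on this read-out lower numbers stand for higher toxicity in this test and higher numbers for lower toxicity in this test. Within the data shown here, compound 1 (`CNc1cc(Oc2c(OC)cc3cc(C#N)ccc3c2OC)nc(Nc2ccc(C#N)cc2)n1`) gives 239000 nM as the only true number so far. Compound 2 (`CCCCNc1cc(Oc2c(OC)cc3cc(C#N)ccc3c2OC)nc(Nc2ccc(C#N)cc2)n1`) reports a limit, > 125000 nM, and no number. Compound 3 (`COc1cc2cc(C#N)ccc2c(OC)c1Oc1cc(NCC(C)C)nc(Nc2ccc(C#N)cc2)n1`) also reports only a limit, > 125000 nM, so its place is not fixed. Among the measured compounds shown here, the series so far shows (the limit of > 125000 nM in this assay, at which 2 of the 3 values shown sit).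

Compound 4 (`CCC(C)Nc1cc(Oc2c(OC)cc3cc(C#N)ccc3c2OC)nc(Nc2ccc(C#N)cc2)n1`) departs from compound 3 as follows: sec-butyl in place of isobutyl on a nitrogen on an aromatic ring. The change is sec-butyl in place of isobutyl on a nitrogen on an aromatic ring, with the same atoms joined differently.

For the measured compounds named here, three measured steps bear on this change: a step that the two limits leave unreadable from compound 2 to compound 3, a step that the limit leaves unreadable from compound 1 to compound 2 and a step that the limit leaves unreadable from compound 1 to compound 3. None of them has a readable size, so none supports a step in either direction. The expected result is a step that the limit leaves unreadable from compound 3 to compound 4, with no shift beyond the scatter anticipated and a further limit quite likely. The estimate for compound 4 is 150000 nM, with an expected range of 80000 nM to 280000 nM.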

Compound 4, half-maximal cytotoxic concentration: > 125000 nM
Compound 4 ended at the assay's limit; the forecaster's own chance of this, stated with the estimate: 70%; the middle value lies beyond the limit too.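

Among these compounds, compound 4 reports only a limit, > 125000 nM, so no step between it and compound 1, compound 2 or compound 3 can be read. The compounds shown leave open whether the butyl, isobutyl and sec-butyl chains of compound 2, compound 3 and compound 4 differ at all in this assay, or how any compares with compound 1.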